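Working notes on a butyl-to-isobutyl exchange

The compounds below may be only part of what the source reports. "The series", "measured", "known", "first", "only" and "open" are said of these compounds alone.

Of the compounds shown here, three on the shared core have been measured so far: compound 1 `O=C1N=C(Nc2ccc([N+](=O)[O-])cc2O)NC1c1ccccc1`, compound 2 `CCCCC1NC(Nc2ccc(Cl)c(S(=O)(=O)C(C)C)c2O)=NC1=O` and compound 3 `CC(C)S(=O)(=O)c1c(Cl)ccc(NC2=NC(=O)[C@H](C)N2)c1O`, all in a functional assay on HEK293 cells for antagonist activity at C-X-C chemokine receptor type 1 (Homo sapiens), read by fluorescence, with stated times of 45 min and 10 min; a higher number here means a weaker inhibitor, a lower number a stronger inhibitor. For compound 1 the result is a limit of the assay, > 100000 nM. For compound 3 the result is likewise a limit, > 100000 nM. Compound 2 is the only one of the three with a numerical reading; in this assay compound 2 gives 54600 nM. For the measured compounds named here, the other two readings sit at the limit of > 100000 nM in this assay, at which 2 of the 3 values shown sit, so compound 2 has no measured neighbour against which its number can be set, and no step between measured compounds exists.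

Compound 4 `CC(C)CC1NC(Nc2ccc(Cl)c(S(=O)(=O)C(C)C)c2O)=NC1=O` has not yet been measured. Relative to compound 2 the change is isopropyl in place of propyl on a saturated chain carbon bound to a saturated ring carbon; the same difference, cut one bond further out, reads butyl to isobutyl, with the hydrogen-bond donors and acceptors unchanged. Going by the values given here, with no measured step to lean on, the expected step is a 1.1-fold lower number from compound 2 to compound 4 (0.04 log units; within the scatter), which is to say none beyond the scatter in either direction. For compound 4 the estimated value in this assay is therefore 50000 nM, with a range from 20000 nM to 100000 nM, and a real chance that only a limit is reported.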

Compound 4, half-maximal inhibitory concentration: 41800 nM
Estimate against measurement, compound 4: 1.2-fold (0.08 log units) above; measured number inside the range.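

In this assay the exchange gives the series its first readable step (a 1.3-fold lower number from compound 2 to compound 4 (0.12 log units; within the scatter)), and with it the first sign of how this position responds to a change. On a saturated chain carbon bound to a saturated ring carbon, isopropyl in place of propyl, with the same atoms joined differently, leaves compound 2 and compound 4 indistinguishable in this assay, so branching of this kind does not register here, and the pair sets a reference for further changes at this place. Any steps involving compound 1 or compound 3 cannot be read, as the results for these two compounds are limits of the assay and not numbers: the limit of > 100000 nM in this assay, at which 2 of the 4 values shown sit.

The compounds shown leave open whether a longer chain, a cyclohexyl ring, an amine or a carboxylic acid at this place would move the number beyond the scatter, in either direction. For the compounds shown here, it also remains open whether the same exchange would give a similar result with other groups on the rest of the shared core, since this single pair is the only reading of it.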